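The source may hold more compounds than are shown below. What is called first, only, known or untested is meant among the compounds shown, and "the series" means these compounds.

Compound 1 `CCC(C)(C)Cc1c[nH]c(CCc2ccc(-c3cnsc3)cc2)n1` gives 10 nM in an in vitro assay on CHO cells for displacement of a labelled ligand from Bombesin receptor subtype-3 (Homo sapiens), read by scintillation counting, with a stated time of 2 h; on this read-out lower numbers stand for stronger inhibition and higher numbers for weaker inhibition.
Compound 2 `CCC(C)(C)Cc1c[nH]c(CCc2ccc(-n3cncn3)cc2)n1` gives 340 nM in this assay.
Compound 3 `CCC(C)(C)Cc1c[nH]c(CCc2ccc(-c3cccnc3)cc2)n1` gives 7.5 nM in this assay.

All three share one core and differ only in the ring attached to the outer benzene ring. Compound 3 gives the lowest number of the three, but its separation from compound 1 is small, a 1.3-fold lower number from compound 1 to compound 3 (0.12 log units; within the scatter), and lies within the scatter, so the two cannot be ranked against each other. Compound 2 stands far apart from both: a 45-fold lower number from compound 2 to compound 3 (1.66 log units; beyond the scatter), and likewise a 34-fold higher number from compound 1 to compound 2 (1.53 log units; beyond the scatter).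

Compound 4 `CCC(C)(C)Cc1c[nH]c(CCc2ccc(N3CCCCC3)cc2)n1` has not yet been measured. It differs from compound 3 in one place: piperidin-1-yl in place of pyridin-3-yl on an aromatic carbon. Among the measured compounds shown here, none of the measured steps swaps an aromatic ring for a non-aromatic one at this position, so no step bears on the change directly. What the measured steps do show is that exchanging the ring here can leave the number within the scatter, as in a 1.3-fold lower number from compound 1 to compound 3 (0.12 log units; within the scatter), or move it by a large amount, as in a 34-fold higher number from compound 1 to compound 2 (1.53 log units; beyond the scatter) and a 45-fold lower number from compound 2 to compound 3 (1.66 log units; beyond the scatter). The expectation for compound 4 in this assay is therefore uncertain: a moderate rise, a 5.3-fold higher number from compound 3 to compound 4 (0.73 log units; beyond the scatter), with a wide range around it. Compound 4 is estimated at 40 nM, between 8 nM and 250 nM.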

Compound 4, half-maximal inhibitory concentration: 28 nM
The estimate for compound 4 lay 1.4-fold (0.15 log units) above the measured number, within the range that was stated.
By their numbers in this assay, from the lowest: compounds 3 and 1 (each within the scatter of the next); then compound 4; then compound 2.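

Replacing the flat aromatic ring with a non-aromatic one costs only a modest amount in this assay (a 3.7-fold higher number from compound 3 to compound 4 (0.57 log units; beyond the scatter)), and the step from the other close aromatic neighbour is of similar size (a 2.8-fold higher number from compound 1 to compound 4 (0.45 log units; beyond the scatter)), so an aromatic ring on the outer benzene ring is not essential for a low number. Aromaticity alone does not set the ranking either, since compound 2 goes against that idea: its aromatic triazole ring gives a much higher number than the non-aromatic piperidin-1-yl ring (a 12-fold lower number from compound 2 to compound 4 (1.08 log units; beyond the scatter)). The entering and leaving rings also match in every count compared here, including heavy atoms and hydrogen-bond acceptors, yet the step lies beyond the scatter, so these counts do not decide the result, and nothing available explains why these rings differ.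

From the compounds shown here alone, it remains open whether a morpholin-4-yl or cyclohexyl ring at this place would fall nearer compound 3 or nearer compound 2. An open-chain amine such as diethylamino would show whether a closed ring is needed here at all.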